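Halogen swaps on the benzyl group of the shared core

A few compounds are considered here, and "the series" means these few. Any claim that something is new, unique, unknown or untested is made for them only; others in the source may bear on it.

Measured compounds:
compound 1 `Clc1ccccc1CSc1nnc(-c2ccc3c(c2)OCCO3)o1`: 22500 nM
compound 2 `O=[N+]([O-])c1ccccc1CSc1nnc(-c2ccc3c(c2)OCCO3)o1`: 23300 nM
compound 3 `Fc1ccccc1CSc1nnc(-c2ccc3c(c2)OCCO3)o1`: 29000 nM

In a functional assay on BGC-823 cells (Homo sapiens) for antiproliferative activity, read by MTT assay, with a stated time of 48 h (on this read-out lower numbers stand for stronger inhibition and higher numbers for weaker inhibition), compound 1 gives 22500 nM. Compound 1 has the lowest of the three numbers, but the steps of a 1.0-fold higher number from compound 1 to compound 2 (0.02 log units; within the scatter) and a 1.3-fold higher number from compound 1 to compound 3 (0.11 log units; within the scatter) are both within the scatter, so no order among compounds 1, 2 and 3 can be claimed; a 1.2-fold higher number from compound 2 to compound 3 (0.10 log units; within the scatter) is likewise within the scatter.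

Compound 4 `Brc1ccc(CSc2nnc(-c3ccc4c(c3)OCCO4)o2)cc1` has not yet been measured. It differs from compound 1 by 4-bromophenyl in place of 2-chlorophenyl on a saturated chain carbon bound to a sulfur. The measured steps all exchange one group for another on the 2-chlorobenzyl unit and none moved the number beyond the scatter; none of them covers the change to 4-bromobenzyl, so they bear only loosely on it. Within the data shown here, with no measured step pointing in either direction, the expected step from compound 1 to compound 4 is a 1.0-fold lower number from compound 1 to compound 4 (0.01 log units; within the scatter), with no direction beyond the scatter. Compound 4 is therefore estimated at 22000 nM, with a range from 8000 nM to 60000 nM.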

Compound 4, half-maximal inhibitory concentration: 22300 nM
Beside the measured number, compound 4's estimate is 1.0-fold (0.01 log units) below it, within the range that was stated.
By their numbers in this assay, from the lowest: compounds 4, 1, 2 and 3 (each within the scatter of the next).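

In this assay, the change from 2-chlorophenyl to 4-bromophenyl gives a 1.0-fold lower number from compound 1 to compound 4 (0.00 log units; within the scatter), and 4-bromophenyl in place of 2-fluorophenyl gives a 1.3-fold lower number from compound 3 to compound 4 (0.11 log units; within the scatter). Unlike the earlier steps, these alter both the halogen and its printed ring position on the saturated chain carbon bound to a sulfur, yet the numbers remain within the scatter. No evidence on hand bears on this result.

Going by these compounds, whether a carboxylic acid or an amine on the phenyl ring, or a longer chain before it, would move the number beyond the scatter remains open.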